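Methyl in place of hydrogen on the amide of compound 1

A few compounds are considered here, and "the series" means these few. Any claim that something is new, unique, unknown or untested is made for them only; others in the source may bear on it.

Compound 1, `CNC(=O)c1cccn(Cc2ccccc2)c1=O`: 3
Compound 2, `CNC(=O)c1cc(C(=O)NC2CCOCC2)cn(Cc2ccccc2)c1=O`: 2.8

In a physicochemical assay for lipophilicity, at pH 7.4 (on this read-out lower numbers stand for lower lipophilicity and higher numbers for higher lipophilicity), compound 1 stands highest of the two numbers; the nearest is compound 2, reached by a number 0.20 log units lower from compound 1 to compound 2 (within the scatter). Compound 3, `CCNC(=O)c1cccn(Cc2ccccc2)c1=O`, differs from compound 1 by methyl in place of hydrogen on a saturated chain carbon bound to an amide-type nitrogen. Going by the values given here, the one measured step concerns a different group and was within the scatter, so it bears only loosely on this change; no measured step matches it. For this change the expected step is a number 0.40 log units higher from compound 1 to compound 3 (beyond the scatter), a modest rise. Compound 3 is therefore expected to give 3.4, within a range from 3 to 3.8.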

Compound 3, distribution coefficient: 3.7
The estimate for compound 3 lay 0.30 log units below the measured number; the measured number falls inside the stated range.
By their numbers in this assay, from the lowest: compounds 2 and 1 (each within the scatter of the next); then compound 3.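

Going from methylcarbamoyl to ethylcarbamoyl gives the first step in this assay that lies beyond the scatter (a number 0.70 log units higher from compound 1 to compound 3 (beyond the scatter)). The earlier step, on an aromatic carbon, stayed within the scatter, so this position on a saturated chain carbon bound to an amide-type nitrogen is the only place shown where one change clearly shifts the number. No available evidence accounts for the size of this step. From the compounds shown here alone, whether a longer chain such as propyl would extend the rise remains open. So does the outcome with an amine or a carboxylic acid on that chain.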